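Chloro in Place of Fluoro: Estimating Compound 4

A few compounds are considered here, and "the series" means these few. Any claim that something is new, unique, unknown or untested is made for them only; others in the source may bear on it.

Measured compounds:
compound 1, `Fc1ccc(-c2ccc(Cn3nnc4ccccc43)cc2)c(F)c1`, 71 nM
compound 2, `Fc1cc(Cl)ccc1-c1ccc(Cn2nnc3ccccc32)cc1`, 28 nM
compound 3, `Fc1ccc(Cn2nnc3c(Br)cccc32)cc1`, 15 nM

Three compounds were tested in a functional assay on cells for positive allosteric modulation of metabotropic glutamate receptor 2 (Homo sapiens), read by fluorescence and calcium flux, with a stated time of 30 min; a higher number here means that more compound is needed for the effect, a lower number that less compound is needed. Compound 1 and compound 2 share a core and differ in one place: chloro in place of fluoro on an aromatic carbon. The step was a 2.5-fold lower number from compound 1 to compound 2 (0.40 log units; beyond the scatter). Compound 3 carries a different core; the difference between the two cores is not broken down here. Compound 3 and compound 2 give values within the usual scatter of each other, so nothing can be said of an order between them; compound 3 against compound 1, however, stands beyond the scatter.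

Compound 4, `Clc1ccc(Cn2nnc3c(Br)cccc32)cc1`, has not yet been measured. It differs from compound 3 in one place: chloro in place of fluoro on an aromatic carbon. This is the same kind of change as that from compound 1 to compound 2, but not the same: in compound 1 the place is meta to a fluoro group, whereas in compound 3 it is not, and the two cores differ.

Within the data shown here, because the one earlier instance gave a 2.5-fold lower number from compound 1 to compound 2 (0.40 log units; beyond the scatter), the step from compound 3 to compound 4 is expected to be of a similar size, a 2.1-fold lower number from compound 3 to compound 4 (0.33 log units; beyond the scatter), with extra width because only a single example of the change, on another core, is known. Compound 4 is therefore estimated at 7 nM, between 3 nM and 20 nM.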

Compound 4, half-maximal effective concentration: 17 nM
The estimate for compound 4 lay 2.4-fold (0.39 log units) below the measured number; the range from low to high includes it.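

On the core of compound 3, chloro in place of fluoro on an aromatic carbon para to a large group gave a 1.1-fold higher number from compound 3 to compound 4 (0.05 log units; within the scatter) in this assay, so compound 3 and compound 4 cannot be told apart in this read-out. Among these compounds, the change therefore did not carry its earlier effect across to this second core, and the two steps differ by more than repeated measurement would explain: the same change on two cores in this assay, a 2.5-fold lower number (0.40 log units; beyond the scatter) from compound 1 to compound 2 and a 1.1-fold higher number (0.05 log units; within the scatter) from compound 3 to compound 4, 2.9-fold (0.46 log units) apart, beyond the scatter of two such steps With only one pair on each core, this does not show which feature of the two structures sets the difference, nor how the same change would behave on a third core; it shows only that the step seen on one core was not a safe guide to the other within this small set.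

The compounds shown leave open whether any other group at this place, such as a methyl, a methoxy group, a nitrile or an amine, would move the number on the core of compound 3, since only fluoro and chloro appear there. Among the compounds shown here, they also leave open how far the bromo group, which compound 3 and compound 4 share, bears on the result, as no pair here replaces it with hydrogen, a methyl or another halogen.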